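This account rests on a few compounds, and the source may have more. Where it says the series, first, only, none or still open, it means among the compounds named here.

Measured so far in a functional assay on MCF7 cells (Homo sapiens) for antiproliferative activity, read by MTT assay, with a stated time of 48 h; a higher number here means a weaker inhibitor, a lower number a stronger inhibitor

compound 1 `Fc1ccc(-c2nn(-c3ccccc3)cc2-c2nc3cc(Br)ccc3[nH]2)cc1` gives 3210 nM
compound 2 `COc1ccc2[nH]c(-c3cn(-c4ccccc4)nc3-c3ccc(F)cc3)nc2c1` gives 970 nM
compound 3 `O=C(OCc1ccccc1)c1ccc2[nH]c(-c3cn(-c4ccccc4)nc3-c3ccc(F)cc3)nc2c1` gives 9240 nM

Compound 2 holds the lowest number of the three, set apart by a 3.3-fold lower number from compound 1 to compound 2 (0.52 log units; beyond the scatter) and by a 9.5-fold higher number from compound 2 to compound 3 (0.98 log units; beyond the scatter) on the other side. Compound 4 `COc1ccc2[nH]c(-c3cn(-c4ccccc4)nc3-c3ccc(Cl)cc3)nc2c1` keeps the methoxy of compound 2 and carries one change: chloro in place of fluoro on an aromatic carbon (chloro in place of fluoro on an aromatic carbon, 4-fluorophenyl to 4-chlorophenyl). For the measured compounds named here, no measured step touches this group. The steps above and a 2.9-fold higher number from compound 1 to compound 3 (0.46 log units; beyond the scatter) exchange only bromo, methoxy and benzyloxycarbonyl, so they bear on it indirectly at best. No step beyond the scatter is expected in this assay and no direction is favoured, with compound 2 at 970 nM as the anchor. The expected step is a 1.1-fold higher number from compound 2 to compound 4 (0.05 log units; within the scatter) and no more. The estimated value for compound 4 is 1100 nM (range 380 nM to 3200 nM).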

Compound 4, half-maximal inhibitory concentration: 1760 nM
Estimate against measurement, compound 4: 1.6-fold (0.20 log units) below; the range from low to high includes it.
By their numbers in this assay, from the lowest: compounds 2, 4 and 1 (each within the scatter of the next, the first and the last beyond it); then compound 3.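

In this assay, for the compounds shown here, chloro in place of fluoro gives a 1.8-fold higher number from compound 2 to compound 4 (0.26 log units; within the scatter), the first reading at this site, as the earlier steps exchanged only bromo, methoxy and benzyloxycarbonyl. On the 4-fluorophenyl group, para to a large group, this swap of one halogen for another therefore leaves compound 2 and compound 4 unseparated. Nothing measured here speaks to the reason for this result.

Open, from the compounds shown here alone, is how this position responds to an amine or a carboxylic acid in place of the halogen. Also open, going by these compounds, is whether chloro behaves alike with bromo or benzyloxycarbonyl in place of methoxy.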